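A few compounds are considered here, and "the series" means these few. Any claim that something is new, unique, unknown or untested is made for them only; others in the source may bear on it.

The series rests on a shared core, seen in compound 1 `Cn1c(=O)c2c(nc(SCCc3ccc(F)cc3)n2C)n(C)c1=O`. Within the data shown here, in an assay on microsomes for inhibition of Amine oxidase [flavin-containing] B (Homo sapiens), read by fluorescence and spectrophotometry, with a stated time of 20 min (on this read-out higher numbers stand for weaker inhibition and lower numbers for stronger inhibition), compound 1 gives 71 nM, the lowest number among the two compounds measured so far. Compound 2 `Cn1c(=O)c2c(nc([S+]([O-])CCc3ccc(Cl)cc3)n2C)n(C)c1=O` carries an oxidised sulfur and a chlorinated ring on its chain; in this assay compound 2 gives 781 nM, a higher number than that of compound 1, and the two values lie beyond the scatter of each other. Among the measured compounds shown here, no single-point step between the measured compounds is available, so this pair shows only that contrast.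

Compound 3 `Cn1c(=O)c2c(nc(SCCCc3ccc(Cl)cc3)n2C)n(C)c1=O` keeps the unoxidised sulfur of compound 1 and differs from it by 4-chlorobenzyl in place of 4-fluorophenyl on a saturated chain carbon, two bonds along the chain from a sulfur. For the measured compounds named here, with no measured step to lean on, the expected shift in this assay is small and toward a higher number, estimated as a 1.7-fold higher number from compound 1 to compound 3 (0.23 log units; within the scatter). Compound 3 is therefore expected to give 120 nM, within a range of 40 nM to 400 nM.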

Compound 3, half-maximal inhibitory concentration: 61 nM
Beside the measured number, compound 3's estimate is 2.0-fold (0.29 log units) above it; the range from low to high includes it.
By their numbers in this assay, from the lowest: compounds 3 and 1 (each within the scatter of the next); then compound 2.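

In this assay, 4-chlorobenzyl in place of 4-fluorophenyl on a saturated chain carbon, two bonds along the chain from a sulfur, gives a 1.2-fold lower number from compound 1 to compound 3 (0.07 log units; within the scatter), so this position accepts either group without a change that can be read in this assay. The step exchanges fluorine for chlorine and adds one carbon in the same move, so its two parts cannot be separated here. No measurement shown explains the match between the two values.

Still open, going by these compounds, is whether unsubstituted benzyl, which would keep the added carbon without the chlorine, gives a value within the scatter of compound 3. Also open, on these data alone, is whether a longer chain, or an amine or a carboxylic acid in place of 4-chlorobenzyl, is accepted at this position.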